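Amide nitrogen substituent in a thiophene-methyl amide series

The source may hold more compounds than are shown below. What is called first, only, known or untested is meant among the compounds shown, and "the series" means these compounds.

Measured so far:
compound 1 `COc1ccc2oc(C(=O)N(Cc3cccs3)c3ccn[nH]3)cc2c1`: 1.1 nM
compound 2 `CCN(Cc1cccs1)C(=O)COc1ccc(C(=O)O)cc1`: "not active" (no number reported)
compound 3 `Cc1ccc(OCC(=O)N(Cc2cccs2)C2CCCCC2)cc1`: 40000 nM

In an assay on HEK293 cells for agonist activity at transient receptor potential cation channel subfamily M member 8 (Homo sapiens), read by fluorescence and calcium flux, with a stated time of 15 min (a higher number here means that more compound is needed for the effect, a lower number that less compound is needed), compound 3 gives the highest of the two numbers recorded, and the gap to compound 1 lies well beyond the scatter. Compound 2 gives only the report shown, without a number. Compound 4 `Cc1ccc(OCC(=O)N(Cc2cccs2)c2ncco2)cc1` differs from compound 3 in one place: 1,3-oxazol-2-yl in place of cyclohexyl on an amide-type nitrogen. For the measured compounds named here, compound 1, the only compound with a low number, also carries an aromatic heterocycle on the amide nitrogen, but it differs from compound 3 in several places, so no step is known for this change alone. A decrease beyond the scatter is expected for compound 4, estimated as a 13-fold lower number from compound 3 to compound 4 (1.12 log units; beyond the scatter). Compound 4 is expected to give 3000 nM in this assay, within 300 nM to 30000 nM.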

Compound 4, half-maximal effective concentration: 0.3 nM
The estimate for compound 4 lay 10000-fold (4.00 log units) above the measured number; measured number below the stated range.
By their numbers in this assay, from the lowest: compound 4; then compound 1; then compound 3.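

In this assay, the substituent on the amide-type nitrogen controls the read-out to a very large degree: 1,3-oxazol-2-yl in place of cyclohexyl gives a 130000-fold lower number from compound 3 to compound 4 (5.12 log units; beyond the scatter) with the rest of the structure unchanged. For the compounds shown here, this is the only single-place step at this position, and it isolates the effect of this change from the other structural differences. Nothing available here accounts for the size of the step.

Going by these compounds, whether phenyl, 2-pyridyl or tetrahydropyranyl on this nitrogen also gives a low number remains open. So does the effect of a methyl group on the 1,3-oxazol-2-yl ring.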